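The source may report more compounds than this note shows. Statements on the series, on what has been measured and on what is new or still open speak of the compounds shown alone.

Compound 1 `Cc1cccc(-c2noc(C3CN(C(=O)C4CCC(C(F)(F)F)CC4)C3)n2)c1`: 1000 nM
Compound 2 `COC1CCN(C(=O)N2CC(c3nc(-c4cccc(Cl)c4)no3)C2)CC1`: > 10000 nM
Compound 3 `Cc1cccc(-c2noc(C3CN(S(=O)(=O)c4ccc(F)cc4)C3)n2)c1`: > 10000 nM

The three compounds share a core and were tested in an assay on HEK293 cells for positive allosteric modulation of metabotropic glutamate receptor 5 (Homo sapiens), read by FLIPR; a higher number here means that more compound is needed for the effect, a lower number that less compound is needed. Compound 1 gives 1000 nM. For compound 2 the assay reports no number but only a limit, > 10000 nM. For compound 3 likewise only a limit is reported, > 10000 nM. Compound 2 therefore stands at the limit of > 10000 nM in this assay, at which 2 of the 3 values shown sit, and nothing in the data tells how far beyond that limit it lies.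

Compound 4 `O=C(N1CCCCC1)N1CC(c2nc(-c3cccc(Cl)c3)no2)C1` is the next compound to be measured in this assay. It differs from compound 2 in one place: hydrogen in place of methoxy on a saturated ring carbon. Among the compounds with values here, no measured pair of compounds differs in a single place, so there is no step against which the size of this change can be set. Within the data shown here, the one compound that gives a number, compound 1, carries a different amide and a different aryl group, and says nothing about the methoxy. With compound 2 at the limit, the expectation for compound 4 is that it stays near that limit, with no movement beyond the scatter. Compound 4 is expected at 10000 nM, in a range from 3000 nM to 30000 nM. The step of a number no higher from compound 2 to compound 4 (the limit leaves the size open) is accordingly estimated to lie within the usual scatter, and the assay is more likely than not to report only a limit again.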

Compound 4, half-maximal effective concentration: 370 nM
Compound 4: middle estimate off by 27-fold (1.43 log units), on the high side, and the stated range ends above it.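

In this assay, within the data shown here, the ring carbon three ring bonds from the ring nitrogen of the six-membered ring proves to matter: hydrogen in place of methoxy there gives an at least 27-fold lower number from compound 2 to compound 4 (1.43 log units; beyond the scatter), the first step that can be read at all. Compound 2 is known only as a limit: the limit of > 10000 nM in this assay, at which 2 of the 4 values shown sit. The step therefore sets a lower bound on the size of this change rather than its full size, but it shows that this one difference, from 4-methoxypiperidin-1-yl to piperidin-1-yl, is enough to separate a compound at the limit from one that gives a number.

The compounds shown leave open whether a methyl, a hydroxyl or a fluorine on the same ring carbon would read like the methoxy or like the hydrogen, and so whether the methoxy is a special case or any group at this place has the same outcome. Among these compounds, they also leave open whether the step would carry over with the aryl group of compound 1 in place of the one shared by compound 2 and compound 4.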